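The source may hold more compounds than are shown below. What is called first, only, known or untested is meant among the compounds shown, and "the series" means these compounds.

Working notes on the series, read in a functional assay on PC-3 cells (Homo sapiens) for antiproliferative activity, read by CCK-8 assay, with a stated time of 6 days; on this read-out lower numbers stand for stronger inhibition and higher numbers for weaker inhibition. Compound 1 `CCN(c1ccc(C#N)c(Cl)c1)c1cc(-c2ccc(F)nc2)ccc1C` reports only a limit, > 30000 nM. Among the compounds with values here, compound 2 `CCN(c1ccc(C#N)c(Cl)c1)c1cc(-c2c[nH]nc2C)ccc1C` gives 9030 nM, the only actual number so far. The next change leads to compound 3 `CCN(c1ccc(C#N)c(Cl)c1)c1cc(-c2cn[nH]c2)ccc1C` and is hydrogen in place of methyl on an aromatic carbon, next to the ring atom that bears a large group. Within the data shown here, the one measured step, an at least 3.3-fold lower number from compound 1 to compound 2 (0.52 log units; beyond the scatter), replaces 6-fluoropyridin-3-yl with 3-methyl-1H-pyrazol-4-yl, so it does not isolate the methyl. With compound 2 at 9030 nM and that step exchanging far more than one methyl, a smaller step is expected here, its direction open with a slight lean towards a lower number. The expected change is a 1.3-fold lower number from compound 2 to compound 3 (0.11 log units; within the scatter). For compound 3 the estimated value is 7000 nM, with an expected range of 2000 nM to 25000 nM.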

Compound 3, half-maximal inhibitory concentration: 15300 nM
Beside the measured number, compound 3's estimate is 2.2-fold (0.34 log units) below it; the range from low to high includes it.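

Taken alone, hydrogen in place of methyl gives a 1.7-fold higher number from compound 2 to compound 3 (0.23 log units; within the scatter), so in this assay the methyl at this carbon, next to the ring atom that bears a large group, makes no difference that can be separated from the scatter. The earlier step therefore cannot be assigned to the methyl: 1H-pyrazol-4-yl in place of 6-fluoropyridin-3-yl gives an at least 1.9-fold lower number from compound 1 to compound 3 (0.29 log units; that floor lies within the scatter), a floor that lies within the scatter. Compound 1 stands only as a limit, so the size of that step stays unfixed: the limit of > 30000 nM in this assay, at which 1 of the 3 values shown sits.

Open, as far as these compounds go, is whether a larger group on this aromatic carbon, such as an ethyl chain, a methoxy or an amine, would move the number beyond the scatter. Also open, from the compounds shown here alone, is whether a methyl on the ring nitrogen would do so.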